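The source may hold more compounds than are shown below. What is called first, only, known or untested is meant among the compounds shown, and "the series" means these compounds.

Measured in a functional assay on MCF7 cells (Homo sapiens) for antiproliferative activity, read by MTT assay, with a stated time of 48 h; on this read-out higher numbers stand for weaker inhibition and lower numbers for stronger inhibition:
- Compound 1 `C=C1[C@H](OC(C)=O)[C@@H](OC(=O)C(C)(C)C)[C@@H](OC(C)=O)C(C)(C)/C=C/[C@H](C)[C@H](OC(=O)c2ccccc2)[C@@]2(O)C[C@@](C)(OC(C)=O)[C@H](OC(C)=O)[C@@H]2[C@H]1OCC(C)C`: > 100000 nM, a limit
- Compound 2 `C=C1[C@H](OC(C)=O)[C@@H](OC(=O)c2cccc(C)c2)[C@@H](OC(C)=O)C(C)(C)/C=C/[C@H](C)[C@H](OC(=O)c2ccccc2)[C@@]2(O)C[C@@](C)(OC(C)=O)[C@H](OC(C)=O)[C@@H]2[C@H]1OCC(C)C`: > 100000 nM, a limit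
- Compound 3 `C=C1[C@H](OC(C)=O)[C@@H](OC(C)=O)[C@@H](OC(C)=O)C(C)(C)/C=C/[C@H](C)[C@H](OC(=O)c2ccccc2)[C@@]2(O)C[C@@](C)(OC(C)=O)[C@H](OC(C)=O)[C@@H]2[C@H]1OCC(C)C`: 74300 nM

Compound 3 is the only one of the three with a true number. The other two compounds give only (the limit of > 100000 nM in this assay, at which 2 of the 3 values shown sit).

Compound 4 `C=C1[C@H](OC(C)=O)[C@@H](OC(C)=O)[C@@H](OC(C)=O)C(C)(C)/C=C/[C@H](C)[C@H](OC(=O)c2ccccc2)[C@@]2(O)C[C@@](C)(OC(=O)C(C)(C)C)[C@H](OC(C)=O)[C@@H]2[C@H]1OCC(C)C` carries tert-butyl in place of methyl on a carbonyl carbon, at a different place on the shared core from the one varied so far: tert-butyl in place of methyl on a carbonyl carbon.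

The closest guide is an at least 1.3-fold lower number from compound 1 to compound 3 (0.12 log units; that floor lies within the scatter), which is the same exchange in reverse at that other place. A second guide is an at least 1.3-fold lower number from compound 2 to compound 3 (0.12 log units; that floor lies within the scatter), where methyl replaces 3-methylphenyl. The floors of both steps lie within the scatter, so neither fixes a size. Together they suggest that a larger group than methyl does not lower the number.

A small step upward is therefore expected in this assay, and it may not exceed the scatter. The expected change is a 1.3-fold higher number from compound 3 to compound 4 (0.13 log units; within the scatter). For compound 4 the estimated value is 100000 nM, with an expected range of 50000 nM to 180000 nM, and the assay may report only a limit.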

Compound 4, half-maximal inhibitory concentration: > 100000 nM
Compound 4: no number, only a limit; the forecaster's own chance of this, stated with the estimate: 55%; the middle value sits exactly at the limit.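

In this assay, from the compounds shown here alone, tert-butyl in place of methyl on a carbonyl carbon, at this second place on the shared core, gives an at least 1.3-fold higher number from compound 3 to compound 4 (0.12 log units; that floor lies within the scatter); only a floor can be read, so the size of the step stays unknown. This position therefore gives no sign of a lower number with the larger group, and compound 4 yields a limit rather than a number. Compound 1 and compound 4 each differ from compound 3 by this same exchange, at two different places, and each ends at the same limit of the assay: the limit of > 100000 nM in this assay, at which 3 of the 4 values shown sit.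

How far the true values of compound 1, compound 2 and compound 4 lie beyond that limit cannot be read. Going by these compounds, whether an amine, a carboxylic acid or a longer chain in place of methyl at this position would give a lower number than compound 3 remains open.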